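Acetyl for phenylsulfonyl on the aryl nitrogen

The source may hold more compounds than are shown below. What is called first, only, known or untested is meant among the compounds shown, and "the series" means these compounds.

Compound 3 `Cc1ccc(CC(CN/C(S)=N/Cc2ccc(NS(=O)(=O)c3ccccc3)cc2)COC(=O)C(C)(C)C)cc1C` gives the highest number of the three measured in an assay on isolated protein for binding affinity to transient receptor potential cation channel subfamily V member 1 (Rattus norvegicus) (on this read-out lower numbers stand for stronger inhibition and higher numbers for weaker inhibition), at 2500 nM. Compound 1 `Cc1ccc(CC(CN/C(S)=N/Cc2ccc(NS(C)(=O)=O)cc2)COC(=O)C(C)(C)C)cc1C` gives 29.3 nM in this assay, and compound 2 `CCCS(=O)(=O)Nc1ccc(C/N=C(\S)NCC(COC(=O)C(C)(C)C)Cc2ccc(C)c(C)c2)cc1` gives 313 nM. The two measured steps into compound 3 both run the same way: an 85-fold higher number from compound 1 to compound 3 (1.93 log units; beyond the scatter) and an 8.0-fold higher number from compound 2 to compound 3 (0.90 log units; beyond the scatter); the first of them is the larger, an 11-fold higher number from compound 1 to compound 2 (1.03 log units; beyond the scatter) being the smaller within that pair.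

Compound 4 `CC(=O)Nc1ccc(C/N=C(\S)NCC(COC(=O)C(C)(C)C)Cc2ccc(C)c(C)c2)cc1` differs from compound 3 by acetyl in place of phenylsulfonyl on a nitrogen on an aromatic ring. Within the data shown here, no measured step exchanges the sulfonyl itself; the steps that bear on it show only that a smaller group on the sulfonyl sulfur goes with a lower number, as in the step from compound 1 to compound 3. Acetyl is small by the counts given, so a lower number than compound 3 is expected in this assay, though the loss of the sulfonyl leaves the size uncertain. The expected step is a 3.6-fold lower number from compound 3 to compound 4 (0.55 log units; beyond the scatter). Compound 4 is estimated at 700 nM in this assay, between 150 nM and 3500 nM.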

Compound 4, inhibition constant: 1700 nM
For compound 4 the middle estimate is 2.4-fold (0.39 log units) below the measured one; low and high end bracket the measured number.
By their numbers in this assay, from the lowest: compound 1; then compound 2; then compounds 4 and 3 (each within the scatter of the next).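

In this assay, the only exchange shown of the sulfonyl itself on a nitrogen on an aromatic ring gives a 1.5-fold lower number from compound 3 to compound 4 (0.17 log units; within the scatter) and so leaves acetyl and phenylsulfonyl unseparated, although acetyl is the smaller group by heavy atoms. The alkylsulfonyl compounds separate clearly from acetyl, with a 58-fold higher number from compound 1 to compound 4 (1.76 log units; beyond the scatter) for acetyl in place of methylsulfonyl and a 5.4-fold higher number from compound 2 to compound 4 (0.73 log units; beyond the scatter) for acetyl in place of propylsulfonyl. The trend of smaller group and lower number seen across compounds 1, 2 and 3 therefore does not extend to compound 4, which goes against it.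

Open, going by these compounds, is whether an ethylsulfonyl or a trifluoromethylsulfonyl group would stay near methylsulfonyl, and whether a propanoyl or methoxycarbonyl group would stay near acetyl. Nothing measured here accounts for the separation between acetyl and the alkylsulfonyl groups.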